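Trimming the side chain of compound 2

This account rests on a few compounds, and the source may have more. Where it says the series, first, only, none or still open, it means among the compounds named here.

In an in vitro ADME assay on microsomes from liver (Homo sapiens) for metabolic stability, tested at 5 uM (a higher number here means that the compound lasts longer, a lower number that the compound disappears faster), compound 1 `CC(C)CCn1nc(-c2ccn(C)c2)c(O)c(C2=NS(=O)(=O)c3cc(NS(C)(=O)=O)ccc3N2)c1=O` gives 0.633 h. Compound 2 `CCC(C)(C)Cn1nc(-c2cccs2)c(O)c(C2=NS(=O)(=O)c3cc(NS(C)(=O)=O)ccc3N2)c1=O` gives > 1 h, which is a limit and not a number. Compound 2 thus sits at the limit of > 1 h in this assay, at which 1 of the 2 values shown sits. Compound 3 `CC(C)(C)Cn1nc(-c2cccs2)c(O)c(C2=NS(=O)(=O)c3cc(NS(C)(=O)=O)ccc3N2)c1=O` differs from compound 2 by hydrogen in place of methyl on a saturated chain carbon, three bonds along the chain from an aromatic nitrogen, turning 2,2-dimethylbutyl into neopentyl. Among the measured compounds shown here, no measured pair shows this change, so only a small step in this assay is expected, with no clear direction. The expected step that the limit leaves unreadable from compound 2 to compound 3 stays within the usual scatter. For compound 3 the estimated half-life is 1.1 h, with a range of 0.7 h to 1.7 h.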

Compound 3, half-life: > 1 h
Compound 3: no number, only a limit; the forecaster's own chance of this, stated with the estimate: 55%; the middle value does not contradict the limit.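

Compound 2 and compound 3 both give only a limit in this assay, so no step between them can be read: the limit of > 1 h in this assay, at which 2 of the 3 values shown sit.

On these data alone, whether 2,2-dimethylbutyl and neopentyl differ in half-life stays open.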